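A few compounds are considered here, and "the series" means these few. Any claim that something is new, unique, unknown or untested is made for them only; others in the source may bear on it.

Measured in a functional assay on HepG2 cells (Homo sapiens) for cytotoxicity, read by sulforhodamine B assay, with a stated time of 48 h; a lower number here means a stronger inhibitor, a higher number a weaker inhibitor:
- compound 1 `Cc1ccc(-c2nc3ccccc3n2CC(=O)N/N=C/c2ccccc2Cl)o1`: 22600 nM
- compound 2 `N=C(Cn1c(-c2ccco2)nc2ccccc21)NN`: 74500 nM
- compound 3 `N#C/C(=C1/SCC(=O)N1c1ccccc1)n1c(-c2ccco2)nc2ccccc21`: 39600 nM

Compound 2 gives 74500 nM, which lies within the scatter of compound 3 at 39600 nM. Compound 1, at 22600 nM, has a lower number than compound 2, and that gap lies beyond the scatter.

Compound 4 `SC1=NNCC(n2c(-c3ccco3)nc3ccccc32)=N1` is the next to be tested. Its change from compound 2 is a group of 7 heavy atoms (3 carbon, 3 nitrogen, 1 sulfur; one six-membered non-aromatic ring with 3 hetero atoms) in place of a group of 5 heavy atoms (2 carbon, 3 nitrogen; no ring), on an aromatic nitrogen. On an aromatic nitrogen, a group with one six-membered non-aromatic ring with 3 hetero atoms stands in place of a group with no ring.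

For the measured compounds named here, no two measured compounds differ in one place only, so the series offers no direct measure of such a change. The nearest guides are the two measured compounds that carry a ring in the group on that nitrogen: compound 1 at 22600 nM and compound 3 at 39600 nM. On that thin basis, a modest move toward a lower number in this assay is expected, and it may not clear the scatter. The expected change is a 2.1-fold lower number from compound 2 to compound 4 (0.33 log units; beyond the scatter). For compound 4 the estimate is 35000 nM, with an expected range of 12000 nM to 90000 nM.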

Compound 4, half-maximal inhibitory concentration: 62100 nM
The estimate for compound 4 lay 1.8-fold (0.25 log units) below the measured number; measured number inside the range.
By their numbers in this assay, from the lowest: compounds 1, 3, 4 and 2 (each within the scatter of the next, the first and the last beyond it).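

In this assay, for the compounds shown here, this pair gives the first direct reading at this position: a 1.2-fold lower number from compound 2 to compound 4 (0.08 log units; within the scatter) when the ring-free group on the aromatic nitrogen is replaced by the group with one six-membered non-aromatic ring with 3 hetero atoms. The exchange is not a small one, as it brings a ring, a sulfur atom and different counts of hydrogen-bond donors and acceptors, yet the two compounds remain within the scatter of each other. In this single pair, then, a ring in the group on that nitrogen is not enough to give a separation beyond the scatter, and nothing measured here explains why the two groups read alike.

Going by these compounds, the ring and the sulfur atom enter together in this step, so their separate contributions remain open, as does the reading of a comparable ring without sulfur. Also open, on these data alone, is how a short chain ending in a carboxylic acid or a primary amine would read on this nitrogen, and whether a phenyl group in place of the furan-2-yl group would change the picture.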